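A few compounds are considered here, and "the series" means these few. Any claim that something is new, unique, unknown or untested is made for them only; others in the source may bear on it.

Working notes on a small series of three compounds: compound 1 `CCC[C@@H](CCn1cncn1)c1ccc(C)cc1`, compound 2 `Clc1ccc([C@H](CCn2cncn2)Cc2ccccc2)cc1` and the still unmeasured compound 3 `Cc1ccc([C@H](CCn2cncn2)Cc2ccccc2)cc1`. In an ADME assay on RD cells (Homo sapiens) for cytotoxicity, read by MTT assay, with a stated time of 3 days (on this read-out higher numbers stand for lower toxicity in this test and lower numbers for higher toxicity in this test), compound 1 gives 74.1 ug/mL and compound 2 gives 21.7 ug/mL. Compound 2 therefore holds the lower of the two numbers, and its gap to compound 1 lies beyond the scatter. Going by the values given here, no measured pair differs in one place only, so that gap cannot be assigned to a single structural change.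

The step followed here leads from compound 2 to compound 3: methyl in place of chloro on an aromatic carbon. This places methyl in place of chloro on an aromatic carbon, para to a large group. Among the compounds with values here, no measured pair in this assay shows this exchange, so its size has to be judged without a direct precedent. Taking compound 2 at 21.7 ug/mL as the anchor, a small upward move that stays within the scatter is expected. The estimate amounts to a 1.4-fold higher number from compound 2 to compound 3 (0.14 log units; within the scatter). For compound 3 the estimated value is 30 ug/mL, with an expected range of 12 ug/mL to 70 ug/mL.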

Compound 3, half-maximal cytotoxic concentration: 117 ug/mL
The estimate for compound 3 lay 3.9-fold (0.59 log units) below the measured number, and the stated range ends below it.
By their numbers in this assay, from the lowest: compound 2; then compounds 1 and 3 (each within the scatter of the next).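

In this assay, the series now holds a direct reading of methyl in place of chloro on an aromatic carbon, para to a large group: a 5.4-fold higher number from compound 2 to compound 3 (0.73 log units; beyond the scatter). This exchange of one heavy atom for one heavy atom, 4-chlorophenyl to 4-methylphenyl, is therefore a step beyond the scatter on this background, whereas phenyl in place of ethyl on a saturated chain carbon, two bonds along the chain from an aromatic carbon, gives a 1.6-fold higher number from compound 1 to compound 3 (0.20 log units; within the scatter) and stays within the scatter with the 4-methylphenyl group held constant. No measurement shown here accounts for the size of the step from chloro to methyl.

Going by these compounds, the exchange of chloro for methyl is read on one background only, so whether a step of this size carries over to the background of compound 1 remains open. Also open, on these data alone, is how methoxy or an amine in this aromatic place, or a longer chain in place of the ethyl or phenyl on the chain carbon, would read in this assay.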